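Replacing naphthalen-2-yl with thiophen-2-yl in compound 3

The compounds below may be only part of what the source reports. "The series", "measured", "known", "first", "only" and "open" are said of these compounds alone.

Of the compounds shown here, three sharing a core have been measured in a physicochemical assay for solubility, at pH 7; a lower number here means a less soluble compound, a higher number a more soluble compound. Compound 1 (`CC(=O)N1CCN(C(=O)N2Cc3c(NC(=O)c4ccc(F)cc4)n[nH]c3C2(C)C)CC1`) returns only a limit, not a number: > 225000 nM. Compound 2 (`CC(C)(C)C(=O)N1Cc2c(NC(=O)c3cccnc3)n[nH]c2C1(C)C`) gives 207000 nM. Going by the values given here, compound 3 (`CN1CCC(C(=O)N2Cc3c(NC(=O)c4ccc5ccccc5c4)n[nH]c3C2(C)C)CC1`) gives 219000 nM, a number within the usual scatter of the one for compound 2.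

Compound 4 (`CN1CCC(C(=O)N2Cc3c(NC(=O)c4cccs4)n[nH]c3C2(C)C)CC1`) differs from compound 3 in one place, with thiophen-2-yl in place of naphthalen-2-yl on a carbonyl carbon. Among the compounds with values here, no two measured compounds differ in only one place, so this change has no direct precedent here.

The best guide is the closeness of the measured numbers. Compound 2 at 207000 nM and compound 3 at 219000 nM agree within the scatter, although their structures differ in more than one place. No change beyond the scatter is therefore expected, and the estimated step is a 1.0-fold lower number from compound 3 to compound 4 (0.02 log units; within the scatter). For compound 4 the expected value is 210000 nM, with an estimated range from 140000 nM to 245000 nM.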

Compound 4, solubility: 155000 nM
Compound 4: the middle estimate sits 1.4-fold (0.13 log units) above what was measured; the measured number falls inside the stated range.
By their numbers in this assay, from the lowest: compounds 4, 2 and 3 (each within the scatter of the next). At a limit, above all of these: compound 1.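

In this assay, going by these compounds alone, this is the first step that can be read at this position: a 1.4-fold lower number from compound 3 to compound 4 (0.15 log units; within the scatter), with thiophen-2-yl in place of naphthalen-2-yl on a carbonyl carbon. So going from two six-membered aromatic rings of carbon only, with 10 heavy atoms, to one five-membered aromatic ring with 1 hetero atom, with 5 heavy atoms, leaves the number within the scatter in this pair. Compound 1 gives a limit and not a number, so it offers no value to set beside this step: the limit of > 225000 nM in this assay, at which 1 of the 4 values shown sits.

From the compounds shown here alone, whether a carboxylic acid or a longer alkyl chain on this carbonyl carbon would carry the number beyond the scatter stays open. One pair also cannot tell whether the same swap would behave alike with the other end of the molecule changed, as it is in compound 1 and compound 2.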